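Swapping the pendant aryl group on a dichlorinated lactone core

A few compounds are considered here, and "the series" means these few. Any claim that something is new, unique, unknown or untested is made for them only; others in the source may bear on it.

Measured compounds:
Compound 1, `COc1ccc(-c2cc(Cl)cc(Cl)c2/C=C/[C@@H]2C[C@@H](O)CC(=O)O2)cc1`: 470 nM
Compound 2, `O=C1C[C@H](O)C[C@@H](/C=C/c2c(F)cc(F)cc2-c2ccc(F)cc2)O1`: 860 nM
Compound 3, `Cc1ccc(C)c(-c2ccc(Cl)c(Cl)c2)c1/C=C/[C@@H]1C[C@@H](O)CC(=O)O1`: 13 nM

These three compounds were tested in an assay for inhibition of 3-hydroxy-3-methylglutaryl-coenzyme A reductase (Rattus norvegicus); a higher number here means a weaker inhibitor, a lower number a stronger inhibitor. Compound 1 gives 470 nM, which is the second highest of the three numbers. Its nearest neighbour is compound 2, whose value of 860 nM lies within the usual scatter of compound 1, so no order between the two can be drawn. Furthest from compound 1 is compound 3, whose 13 nM lies well beyond the scatter, a much lower number.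

The unmeasured compound 4, `O=C1C[C@H](O)C[C@@H](/C=C/c2c(Cl)cc(Cl)cc2-c2ccc(Cl)c(Cl)c2)O1`, arises from compound 1 by a single change: 3,4-dichlorophenyl in place of 4-methoxyphenyl on an aromatic carbon. Within the data shown here, no measured pair shows exactly this exchange, so the expected step rests on what the three values show. Compound 3, which also carries the 3,4-dichlorophenyl group, gives 13 nM, far below the values of compound 1 and compound 2, which carry other pendant aryl groups. On that basis the step for compound 4 is expected to be a clear move to a lower number, a 7.8-fold lower number from compound 1 to compound 4 (0.89 log units; beyond the scatter), beyond the scatter. Compound 4 is therefore estimated at 60 nM, with a range from 15 nM to 250 nM.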

Compound 4, half-maximal inhibitory concentration: 25 nM
For compound 4 the middle estimate is 2.4-fold (0.38 log units) above the measured one, within the range that was stated.
By their numbers in this assay, from the lowest: compounds 3 and 4 (each within the scatter of the next); then compounds 1 and 2 (each within the scatter of the next).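

Among these compounds, on the core of compound 1, the pendant aryl exchange in this assay gives a 19-fold lower number from compound 1 to compound 4 (1.27 log units; beyond the scatter), the first step that can be read at this position, on an aromatic carbon ortho to a large group and meta to two chloro groups. Among the compounds shown here, until now the 3,4-dichlorophenyl group had been seen only in a compound that also differed elsewhere, whereas here the rest of the structure stays fixed and the size of the step belongs to this single exchange. The two groups have the same number of heavy atoms, while 4-methoxyphenyl brings the one hydrogen-bond acceptor and 3,4-dichlorophenyl brings none, but no measurement here says what lies behind the step.

The compounds shown do not separate the loss of the methoxy group from the gain of the two chloro groups, and a plain phenyl, 4-chlorophenyl or 3-chlorophenyl group at this position on the same core would bear on that. They also leave open how a pendant ring carrying an amine or a carboxylic acid would read in this assay at this position.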